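A few compounds are considered here, and "the series" means these few. Any claim that something is new, unique, unknown or untested is made for them only; others in the source may bear on it.

Measured compounds:
- compound 1, `CN(C)CC(=O)N1CCC(NS(=O)(=O)c2cc(S(=O)(=O)c3ccccc3)ccc2C(F)(F)F)CC1`: 100000 nM
- compound 2, `O=C(CN1CCCC1)N1CCC(NS(=O)(=O)c2cc(S(=O)(=O)c3ccccc3)ccc2C(F)(F)F)CC1`: 25000 nM
- compound 3, `CC(C)(C)OC(=O)N1CCC[C@@H]1C(=O)N1CCC(NS(=O)(=O)c2cc(S(=O)(=O)c3ccccc3)ccc2C(F)(F)F)CC1`: 25000 nM

Three members of this series have numbers in a physicochemical assay for solubility; a lower number here means a less soluble compound, a higher number a more soluble compound. Compound 1 gives 100000 nM and is the highest of the three. Compound 2 gives 25000 nM, and the step of a 4.0-fold lower number from compound 1 to compound 2 (0.60 log units; beyond the scatter) lies beyond the scatter. Compound 3 gives 25000 nM; the step of a 4.0-fold lower number from compound 1 to compound 3 (0.60 log units; beyond the scatter) is of the same size, while no change at the digits printed from compound 2 to compound 3 (within the scatter), so compound 3 stands level with compound 2 at the digits shown, the two of them together the lowest numbers measured, with compound 1 the furthest away.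

Compound 4, `CCNC(=O)N1CCC[C@H]1C(=O)N1CCC(NS(=O)(=O)c2cc(S(=O)(=O)c3ccccc3)ccc2C(F)(F)F)CC1`, has not been measured in this assay. It differs from compound 3 in one place: 1-(ethylcarbamoyl)pyrrolidin-2-yl in place of 1-(tert-butoxycarbonyl)pyrrolidin-2-yl on a carbonyl carbon. For the measured compounds named here, none of the measured steps exchanges the group on the pyrrolidine nitrogen; the steps from compound 1 to compound 2 and from compound 1 to compound 3 concern the other end of the amide and offer no direct read on this change. The expectation therefore rests on compound 3 alone, with wide bounds. The step is expected to be a 1.6-fold higher number from compound 3 to compound 4 (0.20 log units; within the scatter), small and within the scatter around the value of compound 3. Compound 4 is thus expected to give about 40000 nM, in the range 15000 nM to 120000 nM.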

Compound 4, solubility: 100000 nM
Beside the measured number, compound 4's estimate is 2.5-fold (0.40 log units) below it; low and high end bracket the measured number.
By their numbers in this assay, from the lowest: compounds 2 and 3 (each within the scatter of the next); then compounds 1 and 4 (each within the scatter of the next).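

In this assay, the group on the pyrrolidine nitrogen now has a first read: 1-(ethylcarbamoyl)pyrrolidin-2-yl in place of 1-(tert-butoxycarbonyl)pyrrolidin-2-yl on the carbonyl carbon gives a 4.0-fold higher number from compound 3 to compound 4 (0.60 log units; beyond the scatter), so the number at this position responds to what sits on that nitrogen and is not fixed by the pyrrolidin-2-yl unit itself. The same group gives a 4.0-fold higher number from compound 2 to compound 4 (0.60 log units; beyond the scatter), and no change at the digits printed from compound 1 to compound 4 (within the scatter), showing that a substituted pyrrolidin-2-yl here can match the number of the small (dimethylamino)methyl group, which compound 3 alone did not show. No measurement shown accounts for these steps.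

The structures of compound 3 and compound 4 are drawn with opposite configuration at the defined stereocentre, so the step cannot be assigned to the nitrogen group alone until both groups are seen in one configuration. Also open, from the compounds shown here alone, is whether the number holds with a longer chain on the urea nitrogen, a simple acetyl group, or the free pyrrolidine amine.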